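Ring in place of chain on the pyrimidine of compound 3

The source may report more compounds than this note shows. Statements on the series, on what has been measured and on what is new or still open speak of the compounds shown alone.

Of the compounds shown here, three sharing one core have been measured in a functional assay on CHO-K1 cells for antagonist activity at C-X-C chemokine receptor type 3 (Homo sapiens), read by FLIPR, with a stated time of 10 min; a higher number here means a weaker inhibitor, a lower number a stronger inhibitor. Compound 1 `Cc1ncc(-c2nc(C(F)(F)F)sc2N2CCN(C(=O)Cn3nc(C)nc3C)[C@H](C)C2)cn1` gives 19 nM. Compound 2 `CCc1ncc(-c2nc(C(F)(F)F)sc2N2CCN(C(=O)Cn3nc(C)nc3C)[C@H](C)C2)cn1` gives 14 nM, and compound 3 `CCCc1ncc(-c2nc(C(F)(F)F)sc2N2CCN(C(=O)Cn3nc(C)nc3C)[C@H](C)C2)cn1` gives 4.4 nM. The step of a 1.4-fold lower number from compound 1 to compound 2 (0.13 log units; within the scatter) is within the scatter, so compounds 1 and 2 cannot be told apart. Lengthening the chain further gave a 4.3-fold lower number from compound 1 to compound 3 (0.64 log units; beyond the scatter) and a 3.2-fold lower number from compound 2 to compound 3 (0.50 log units; beyond the scatter), both modest but real. Compound 3 therefore stands lowest of the three numbers, separated from both others by steps beyond the scatter.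

Compound 4 `Cc1nc(C)n(CC(=O)N2CCN(c3sc(C(F)(F)F)nc3-c3cnc(N4CCCC4)nc3)C[C@H]2C)n1` differs from compound 3 by pyrrolidin-1-yl in place of propyl on an aromatic carbon. The group sits on an aromatic carbon of a six-membered aromatic ring with two nitrogen atoms, the same position where the chain was lengthened in the measured steps. Those steps both lowered the number as the group at this position grew, yet they concern an open chain, while a five-membered ring with a nitrogen atom enters here, and nothing measured shows how such a ring behaves at this position. The expectation for compound 4 is a number close to that of compound 3, with the step of a 1.3-fold lower number from compound 3 to compound 4 (0.10 log units; within the scatter) expected to lie within the scatter. Compound 4 is thus estimated at 3.5 nM, in the range 1.2 nM to 12 nM.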

Compound 4, half-maximal inhibitory concentration: 3.5 nM
Beside the measured number, compound 4's estimate shows no gap at the digits printed; measured number inside the range.
By their numbers in this assay, from the lowest: compounds 4 and 3 (each within the scatter of the next); then compounds 2 and 1 (each within the scatter of the next).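

Placing a ring on this carbon, in this assay, gives a 1.3-fold lower number from compound 3 to compound 4 (0.10 log units; within the scatter), so the position accepts pyrrolidin-1-yl, a closed ring with one nitrogen atom, as well as the open propyl chain, something the chain-only series could not show. The ring also stands clear of the two shorter chains, with a 4.0-fold lower number from compound 2 to compound 4 (0.60 log units; beyond the scatter) and a 5.4-fold lower number from compound 1 to compound 4 (0.73 log units; beyond the scatter), so compound 4 joins compound 3 in a group separated from compound 1 and compound 2 by steps beyond the scatter. No measurement at hand offers a reason why this ring and this chain cannot be told apart here.

This single swap changes the ring and the nitrogen atom together, so the compounds shown cannot say which of the two matters, and an open amine such as diethylamino, or a plain cyclopentyl ring, would be needed to pull them apart. Also open, on these data alone, is what lies further along in size, such as a longer butyl chain or the six-membered piperidin-1-yl and morpholin-4-yl rings, which could show whether the number stays at this level or moves again.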